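Working notes: double-bond geometry from compound 2 to compound 4

The source may report more compounds than this note shows. Statements on the series, on what has been measured and on what is new or still open speak of the compounds shown alone.

Measured so far in a functional assay on K562 cells (Homo sapiens) for cytotoxicity, read by MTT assay, with a stated time of 72 h (on this read-out higher numbers stand for weaker inhibition and lower numbers for stronger inhibition), and given here per compound:
- compound 1 `CCCCC(C)C[C@]1(CC)O[C@H]1[C@]1(CC)C=CC(=O)O1` gives > 50000 nM as a limit of the assay
- compound 2 `CCCCC(C)C/C(=C/[C@@]1(CC)OC(=O)C[C@@H]1O)CC` gives 49200 nM as a number
- compound 3 `CC/C=C/[C@H]1C[C@](O)(CC)[C@@H]([C@]2(CC)OC(=O)C[C@@H]2O)[C@@H]1C` gives 19400 nM as a number

Compound 2 gives 49200 nM as the higher of the two numerical values in the series, and compound 3 gives 19400 nM as the lower one, a gap beyond the usual scatter.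

The next compound to be measured is compound 4 `CCCCC(C)C/C(=C\[C@@]1(CC)OC(=O)C[C@@H]1O)CC` and its relation to compound 2 is this: the two compounds have the same atoms and bonds; at least one stereo element is drawn with a configuration in one of them and without one in the other: 1 of 4 stereo elements differ; a double bond is drawn E in compound 2 and Z in compound 4 (a double bond is drawn E in compound 2 and Z in compound 4).

Within the data shown here, no step between two compounds differing in one place has been measured, so the data give neither a size nor a direction for this change. The expectation therefore rests on compound 2 at 49200 nM and on the atoms and bonds staying the same. Expected for the change is a 1.2-fold lower number from compound 2 to compound 4 (0.09 log units; within the scatter) in this assay and thus no shift beyond the scatter. A reported limit in place of a number remains possible for compound 4.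

The estimate for compound 4 is 40000 nM with an expected range from 18000 nM to 50000 nM on the same read-out.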

Compound 4, half-maximal inhibitory concentration: 2200 nM
Compound 4: the middle estimate sits 18-fold (1.26 log units) above what was measured; measured number below the stated range.
By their numbers in this assay, from the lowest: compound 4; then compound 3; then compound 2. At a limit, above all of these: compound 1.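

With atoms and bonds unchanged, turning the double bond from E to Z gives a 22-fold lower number from compound 2 to compound 4 (1.35 log units; beyond the scatter) in this assay, so the geometry at this one double bond is enough to move the read-out well beyond the scatter. Among these compounds, the earlier compounds offered no step between compounds differing in one place, and this is the first size and direction the series provides for any single change, here showing that the Z form goes with the lower number and that this double bond cannot be treated as an indifferent part of the structure. One caution applies to reading the step as a clean E to Z comparison: the fact that one of compounds 2 and 4 is drawn with a defined configuration and the other without, at the place where they differ

Going by these compounds, whether the step keeps its size when the hydroxyl group gives way to an amine, or when a longer chain replaces the alkyl part, remains open. Also open is whether the same difference between the two geometries appears in any other cell line, since the compounds shown here carry a value from a single cytotoxicity read-out only.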